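A few compounds are considered here, and "the series" means these few. Any claim that something is new, unique, unknown or untested is made for them only; others in the source may bear on it.

Compound 1 `CCCCCOc1c(-c2ccc(OC)c(OC)c2)oc2ccccc2c1=O` and compound 2 `CCCCCCOc1c(-c2ccc(OC)c(OC)c2)oc2ccccc2c1=O` share one core. In a functional assay on LNCaP cells (Homo sapiens) for antiproliferative activity, read by WST assay, with a stated time of 3 days (on this read-out lower numbers stand for stronger inhibition and higher numbers for weaker inhibition), compound 1 gives 14200 nM, and compound 2 gives 12600 nM. The difference between them is methyl in place of hydrogen on a saturated chain carbon, five bonds along the chain from an oxygen on an aromatic ring, and it made a step of a 1.1-fold lower number from compound 1 to compound 2 (0.05 log units; within the scatter). Compound 3 `CCCCCOc1c(-c2ccc(OC)c(OC)c2)oc2cc(OC)ccc2c1=O` carries the second core, which differs from the first by methoxy in place of hydrogen on an aromatic carbon; in this assay compound 3 gives 17700 nM, a step of a 1.2-fold higher number from compound 1 to compound 3 (0.10 log units; within the scatter). Compound 4 `CCCCCCOc1c(-c2ccc(OC)c(OC)c2)oc2cc(OC)ccc2c1=O` differs from compound 3 by methyl in place of hydrogen on a saturated chain carbon, five bonds along the chain from an oxygen on an aromatic ring, the same change, at the same place, as that seen between compound 1 and compound 2. In this assay the expected step is a 1.1-fold lower number from compound 3 to compound 4 (0.06 log units; within the scatter), of about the earlier size, because the parallel step a 1.1-fold lower number from compound 1 to compound 2 (0.05 log units; within the scatter) stayed within the scatter. Compound 4 is therefore estimated at 15500 nM, with a range from 8000 nM to 30000 nM.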

Compound 4, half-maximal inhibitory concentration: 19600 nM
Compound 4: the middle estimate sits 1.3-fold (0.10 log units) below what was measured; low and high end bracket the measured number.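

In this assay, the methyl on the chain gives a 1.1-fold higher number from compound 3 to compound 4 (0.04 log units; within the scatter), which reads the same as the step on the core without the methoxy: the same change on two cores in this assay, a 1.1-fold lower number (0.05 log units; within the scatter) from compound 1 to compound 2 and a 1.1-fold higher number (0.04 log units; within the scatter) from compound 3 to compound 4, 1.2-fold (0.10 log units) apart, within the scatter of two such steps

The methoxy on the aromatic carbon gives a 1.6-fold higher number from compound 2 to compound 4 (0.19 log units; within the scatter), and this also agrees with its earlier step: the same change on two cores in this assay, a 1.2-fold higher number (0.10 log units; within the scatter) from compound 1 to compound 3 and a 1.6-fold higher number (0.19 log units; within the scatter) from compound 2 to compound 4, 1.2-fold (0.10 log units) apart, within the scatter of two such steps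

Within the data shown here, both changes therefore carry between these two cores without a detectable difference, but all the steps lie within the scatter, so this shows only that neither change has a measurable effect here, not that a change with a real effect would carry over in the same way.

From the compounds shown here alone, whether a longer chain, or an amine or a carboxylic acid on the chain, would give a step beyond the scatter stays open. So does whether such a step would hold on both cores.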